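This account rests on a few compounds, and the source may have more. Where it says the series, first, only, none or still open, it means among the compounds named here.

Working notes on the series. Compound 1 `Cc1[nH]c2ccccc2c1C1=C(Br)C(=O)C(Br)=C(c2c(C)[nH]c3ccccc23)C1=O` and compound 2 `COc1ccc2[nH]c(C)c(C3=C(Br)C(=O)C(Br)=C(c4c(C)[nH]c5ccc(OC)cc45)C3=O)c2c1` share a core and have both been run in a functional assay on MCF7 cells (Homo sapiens) for antiproliferative activity, read by CCK-8 assay, with a stated time of 48 h; on this read-out higher numbers stand for weaker inhibition and lower numbers for stronger inhibition. In this assay compound 1 gives 8.33 ug/mL, the higher of the two numbers as written, though the gap to compound 2, which gives 4.72 ug/mL, is within the usual scatter, so the two stand together and no difference between them can be read. Among the measured compounds shown here, no step between measured compounds bears on the change considered next.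

Compound 3 `Cc1ccc(-c2[nH]c3ccccc3c2C2=C(Br)C(=O)C(Br)=C(c3c(C)[nH]c4ccccc34)C2=O)cc1` is not yet measured. It differs from compound 1 in one place: 4-methylphenyl in place of methyl on an aromatic carbon. The group that enters is 4-methylphenyl in place of methyl, on an aromatic carbon of a five-membered aromatic ring with 1 nitrogen, part of a fused system of two rings. For the measured compounds named here, nothing among the measured compounds shows how this assay answers such a change; the only measured comparison, compound 1 against compound 2, concerns a different part of the core. The step from compound 1 to compound 3 is therefore expected to be small, a 1.2-fold lower number from compound 1 to compound 3 (0.08 log units; within the scatter), in either direction and not clearly beyond the scatter. Compound 3 is accordingly estimated at 7 ug/mL, with a range from 2.5 ug/mL to 20 ug/mL.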

Compound 3, half-maximal inhibitory concentration: 6.85 ug/mL
The estimate for compound 3 lay 1.0-fold (0.01 log units) above the measured number, within the range that was stated.
By their numbers in this assay, from the lowest: compounds 2, 3 and 1 (each within the scatter of the next).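

In this assay, the aromatic carbon next to the ring nitrogen and next to the ring atom that bears a large group accepts 4-methylphenyl in place of methyl with a 1.2-fold lower number from compound 1 to compound 3 (0.08 log units; within the scatter). This exchange of 1 heavy atom for 7 heavy atoms, which adds one six-membered aromatic ring of carbon only, therefore leaves no difference that can be read, whereas compound 1 and compound 2 differ in another part of the core and gave no reading at this position. No measurement other than the assay numbers bears on this result.

The compounds shown leave open how this position answers to a carboxylic acid, an amine or a longer alkyl chain in place of methyl, since all the reading here rests on a single step with a hydrocarbon group entering. They also leave open whether a phenyl ring carrying a substituent other than methyl, such as 4-aminophenyl or 4-carboxyphenyl, would stay within the scatter of compound 3.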